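Benzyloxy to 2-methoxyethoxy on the shared core

The source may report more compounds than this note shows. Statements on the series, on what has been measured and on what is new or still open speak of the compounds shown alone.

Of the compounds shown here, three have been read in an ADME assay on BJ cells (Homo sapiens) for cytotoxicity, with a stated time of 72 h; on this read-out higher numbers stand for an effect only at larger amounts of compound and lower numbers for an effect already at smaller amounts: compound 1 (`Nc1nc(-c2ccc(Cl)cc2)nn1-c1ncnc2cc(Cl)ccc12`), compound 2 (`COCCOc1cc2ncnc(-n3nc(-c4ccccn4)nc3N)c2cc1OCCOC`) and compound 3 (`COc1cc2ncnc(-n3nc(-c4ccccn4)nc3N)c2cc1OCc1ccccc1`). Compound 1 gives > 47000 nM as a limit of the assay. Compound 2 gives > 27000 nM as a limit too. Compound 3 gives > 27000 nM and so stands only at a limit, without a number of its own. Compound 4 (`COCCOc1cc2c(-n3nc(-c4ccccn4)nc3N)ncnc2cc1OC`) differs from compound 3 by methoxymethyl in place of phenyl on a saturated chain carbon bound to an oxygen on an aromatic ring with methoxymethyl in place of phenyl on a saturated chain carbon bound to an oxygen on an aromatic ring. Compound 2 carries 2-methoxyethoxy and gives > 27000 nM as a limit, so no step beyond the scatter is expected in this assay in either direction. The estimated move is a step that the limit leaves unreadable from compound 3 to compound 4 and stays within the scatter. For compound 4 the estimate is 29000 nM with an expected range from 15000 nM to 50000 nM in this read-out.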

Compound 4, half-maximal effective concentration: > 13000 nM
Compound 4: no number, only a limit (the forecaster's own chance of this, stated with the estimate: 85%); the middle value is on the limit's open side.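

In this assay compound 4 gives > 13000 nM, a limit. Going by these compounds alone, compound 2 and compound 3 also stand only at limits, so no step to compound 4 can be read. Whether benzyloxy to 2-methoxyethoxy shifts the read-out at all stays open, with no compound shown having a number of its own.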